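Trimming an isopropyl amide to an ethyl amide

This account rests on a few compounds, and the source may have more. Where it says the series, first, only, none or still open, it means among the compounds named here.

Measured compounds:
Compound 1, `CCCNS(=O)(=O)c1ccc(Nc2ncc3c(n2)N(C2CCCC2)[C@H](CC)C(=O)N3C)cc1`, gives 548 nM.
Compound 2, `CCCNS(=O)(=O)c1ccc(Nc2ncc3c(n2)N(c2ccn(C)n2)C(CC)C(=O)N3C)cc1`, gives 2260 nM.
Compound 3, `CC[C@@H]1C(=O)N(C)c2cnc(-n3ccc4cc(C(=O)NC(C)C)ccc43)nc2N1C1CCCC1`, gives 786 nM.

All three numbers come from a functional assay on K562 cells (Homo sapiens) for antiproliferative activity, read by CCK-8 assay, with a stated time of 72 h; a lower number here means a stronger inhibitor of growth, a higher number a weaker inhibitor of growth. Among them, compound 3 stands second highest. Its nearest neighbour is compound 1, whose number lies within the scatter of compound 3, so the two cannot be told apart here. Its furthest neighbour is compound 2, whose number lies beyond the scatter and is the higher of the two, so compound 2 is the weaker growth inhibitor of that pair.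

Compound 4, `CCNC(=O)c1ccc2c(ccn2-c2ncc3c(n2)N(C2CCCC2)[C@H](CC)C(=O)N3C)c1`, has not yet been measured. It differs from compound 3 in one place: hydrogen in place of methyl on a saturated chain carbon bound to an amide-type nitrogen and a saturated chain carbon. The shared core and the rest of the molecule stay as they are.

Within the data shown here, no measured pair here shows the same change, so there is no direct step to lean on. A change this small, at the far end of a side chain, is expected to move the number little if at all: the estimate is a step from compound 3 to compound 4 of a 1.0-fold higher number from compound 3 to compound 4 (0.01 log units; within the scatter), most likely within the scatter. Compound 4 is therefore expected to give about 800 nM, with a plausible range from 350 nM to 1800 nM.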

Compound 4, concentration for 50% growth inhibition: 428 nM
For compound 4 the middle estimate is 1.9-fold (0.27 log units) above the measured one, and the stated range covers the measured number.
By their numbers in this assay, from the lowest: compounds 4, 1 and 3 (each within the scatter of the next); then compound 2.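

In this assay, among these compounds, trimming isopropylcarbamoyl to ethylcarbamoyl gives a 1.8-fold lower number from compound 3 to compound 4 (0.26 log units; within the scatter), the first direct reading of any change at this position. The two compounds therefore cannot be told apart, and within the resolution of this measurement, removing this one methyl from the saturated chain carbon bound to the amide-type nitrogen leaves growth inhibition intact. Nothing in the available data offers an explanation for the size of this step.

This single pair shows only that the ethyl and isopropyl amides cannot be separated, so it leaves open how much change the side chain can take, which a longer chain such as n-butyl, a ring such as cyclopropyl or the unsubstituted primary amide would help to define. It also leaves open whether the amide itself is needed in this assay, a question that a carboxylic acid or an amine at the same place on the otherwise unchanged molecule could address.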